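The compounds below may be only part of what the source reports. "The series", "measured", "known", "first", "only" and "open" are said of these compounds alone.

Of the compounds shown here, three have so far been tested in a functional assay on U-87MG ATCC cells for antiproliferative activity against U-87 MG (Homo sapiens), read by MTT assay, with a stated time of 48 h, tested at 50 uM; on this read-out higher numbers stand for a weaker effect at the one concentration tested and lower numbers for a stronger effect. Compound 1 `COc1ccc(-c2nc(C)c(C(=O)CSc3nc(N)c(C#N)c(-c4ccccc4)n3)s2)cc1` gives 16.5%. Compound 2 `COc1ccc(-c2nc(C)c(C(=O)CSc3nc(-c4cccc(OC)c4)c(C#N)c(=O)[nH]3)s2)cc1` gives 43.2%, and compound 3 `COc1cccc(-c2nc(SCC(=O)c3sc(-c4ccccc4)nc3C)[nH]c(=O)c2C#N)c1` gives 80.3%. Compound 1 therefore has the lowest number of the three, and its gaps to compound 2 and to compound 3 both lie beyond the scatter. Compound 3 and compound 2 differ in a single place: methoxy in place of hydrogen on an aromatic carbon. That change produced a step of a number 37.1 percentage points lower from compound 3 to compound 2 (beyond the scatter). Compound 4 `COc1ccc(-c2nc(C)c(C(=O)CSc3nc(N)c(C#N)c(-c4ccc(OC)cc4)n3)s2)cc1` has not yet been measured in this assay; it differs from compound 1 by methoxy in place of hydrogen on an aromatic carbon, the same change made on a different core. The difference between the core of compound 1 and the core of compound 3 is not broken down here. Because compound 1 already sits low at 16.5%, a drop as large as the earlier one cannot be repeated in the same direction, so the step made by this change is expected to be smaller: a number 4.5 percentage points lower from compound 1 to compound 4 (within the scatter). Compound 4 is expected to give around 12%, somewhere between 4% and 30%.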

Compound 4, a percentage reported as activity, at one concentration (the size of the read-out at that concentration, not a potency): 13%
The estimate for compound 4 lay 1 percentage points below the measured number, within the range that was stated.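

In this assay, methoxy in place of hydrogen on the core of compound 1, the change from phenyl to 4-methoxyphenyl, gives a number 3.5 percentage points lower from compound 1 to compound 4 (within the scatter), so here it leaves the read-out within the usual scatter. Among the compounds shown here, the change therefore did not carry the same size of step from one core to the other: the same change on two cores in this assay, a number 37.1 percentage points lower (beyond the scatter) from compound 3 to compound 2 and a number 3.5 percentage points lower (within the scatter) from compound 1 to compound 4, 33.6 percentage points apart, beyond the scatter of two such steps These two pairs show only that the step cannot be assumed to transfer, and they do not show whether the gap comes from the core, from the ring that receives the methoxy, or from how low compound 1 already stands at 16.5%.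

The compounds shown leave open what an amine, a hydroxyl or a longer chain such as ethoxy would do in this place on the core of compound 1. With a read-out at a single concentration, they also leave open how compound 1 and compound 4 would compare across a range of concentrations.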